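The compounds below may be only part of what the source reports. "The series", "measured", "known", "first", "only" and "open" are said of these compounds alone.

Compound 1, `CCNC1=Nc2ccc(Cl)cc2C(C)(C)C1`, gives 89.7% in a functional assay on MDA-MB-231 cells (Homo sapiens) for cytotoxicity, read by MTT assay, with a stated time of 72 h, tested at 1 uM, in the absence of a further agent; a lower number here means a stronger effect, a higher number a weaker effect of the compound at the concentration tested.
Compound 2, `CC1(C)CC(NCCCCO)=Nc2ccc(Cl)cc21`, gives 87.6% in this assay.

Of the two numbers, compound 2 gives the lower one, but the step of a number 2.1 percentage points lower from compound 1 to compound 2 (within the scatter) is within the scatter, so the two compounds are not told apart by this assay. Compound 3, `CN(C)CCCNC1=Nc2ccc(Cl)cc2C(C)(C)C1`, differs from compound 2 in one place: dimethylamino in place of hydroxymethyl on a saturated chain carbon, three bonds along the chain from an amine nitrogen. For the measured compounds named here, the only step that touches the same region is the one in which the chain end of compound 2 was built out from compound 1, and that step, a number 2.1 percentage points lower from compound 1 to compound 2 (within the scatter), was within the scatter. A swap at the end of the same chain is therefore expected to change this assay by no more than the scatter, and the estimate for compound 3 is 87%, with a range from 72% to 97%, an expected step of a number 0.6 percentage points lower from compound 2 to compound 3 (within the scatter).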

Compound 3, a percentage reported as activity, at one concentration (the size of the read-out at that concentration, not a potency): 54.1%
Compound 3: middle estimate off by 32.9 percentage points, on the high side; the measured number lies below the stated range.
By their numbers in this assay, from the lowest: compound 3; then compounds 2 and 1 (each within the scatter of the next).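

The end of this chain is not a silent place: with 3-(dimethylamino)propyl in place of 4-hydroxybutyl, this assay shows a number 33.5 percentage points lower from compound 2 to compound 3 (beyond the scatter). The earlier pair gave no sign of this, since a chain ending in hydroxymethyl could not be told apart from the simpler chain. The same holds with the simpler chain as the starting point, which gives a number 35.6 percentage points lower from compound 1 to compound 3 (beyond the scatter), so the change in the number goes with the dimethylamino chain end in these compounds. No measurement here explains why this group has such an effect.

From the compounds shown here alone, whether a primary amine, a morpholine or a carboxylic acid at the chain end would give a similar number remains open. So does how a shorter or longer chain carrying the same dimethylamino group would behave.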